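The source may report more compounds than this note shows. Statements on the series, on what has been measured and on what is new or still open speak of the compounds shown alone.

Compound 1 `NC1CCC(CN2CCN(c3cc(=O)c4cc(C(F)(F)F)cc([N+](=O)[O-])c4s3)CC2)CC1` is the most stable of the three measured compounds in an ADME assay on cells (Hepatocyte, Mus musculus) for metabolic stability, with a stated time of 30 min; a higher number here means that more of the compound is left, a lower number that less of the compound is left: it gives 107%, the highest number of the three. Its two measured neighbours both carry an ester in place of the amino group on the saturated ring. Compound 2 `Cc1ccc(C(=O)OC2CCC(CN3CCN(c4cc(=O)c5cc(C(F)(F)F)cc([N+](=O)[O-])c5s4)CC3)CC2)cc1` gives 18% in this assay, and compound 3 `O=C(OC1CCC(CN2CCN(c3cc(=O)c4cc(C(F)(F)F)cc([N+](=O)[O-])c4s3)CC2)CC1)C1CCCCC1` gives 1.2%. The step of a number 89 percentage points lower from compound 1 to compound 2 (beyond the scatter) and the step of a number 105.8 percentage points lower from compound 1 to compound 3 (beyond the scatter) are both large, while the step of a number 16.8 percentage points lower from compound 2 to compound 3 (beyond the scatter) between the two esters is modest.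

Compound 4 `O=c1cc(N2CCN(CC3CCCCC3)CC2)sc2c([N+](=O)[O-])cc(C(F)(F)F)cc12` has not been measured in this assay. It differs from compound 1 in one place: hydrogen in place of amino on a saturated ring carbon. The measured steps that bear on this change are the two that also remove the amino group, from compound 1 to compound 2 and from compound 1 to compound 3; both were large and downward. Neither of them puts a plain hydrogen in its place, so they only show that losing the amino group on this ring has gone together with a large loss so far. For compound 4 a downward step is therefore expected, a number 62 percentage points lower from compound 1 to compound 4 (beyond the scatter), with wide uncertainty. The expected value for compound 4 in this assay is 45%, within a range from 10% to 85%.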

Compound 4, percent of the compound remaining in the Hepatocyte assay: 80.6%
Compound 4: the middle estimate sits 35.6 percentage points below what was measured; low and high end bracket the measured number.
By their numbers in the Hepatocyte assay, from the lowest: compound 3; then compound 2; then compound 4; then compound 1.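

In the Hepatocyte assay, taking the amino group away and leaving only hydrogen gives a much smaller step than the esters do: a number 26.4 percentage points lower from compound 1 to compound 4 (beyond the scatter) is modest, whereas a number 79.4 percentage points higher from compound 3 to compound 4 (beyond the scatter) and a number 62.6 percentage points higher from compound 2 to compound 4 (beyond the scatter) are both large, so the loss of the amino group alone does not account for the low numbers of the two esters. The same single change, which leaves the rest of the molecule untouched, goes with a very large drop in the other property followed here, in a physicochemical assay for solubility, read by HPLC, with a stated time of 20 min; a higher number here means a more soluble compound, a lower number a less soluble compound: the measured solubility of compound 1, 43.9 ug/mL, and of compound 4, < 0.1 ug/mL, an at least 430-fold lower number (2.64 log units; beyond the scatter) In the physicochemical assay compound 1 gives 43.9 ug/mL. In the physicochemical assay compound 4 gives < 0.1 ug/mL, which is a limit of the assay and not a number.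

The compounds shown leave open whether another group on this saturated ring carbon, such as a hydroxyl, a methylamino group or a carboxylic acid, would keep the number in the Hepatocyte assay close to that of compound 1 while also holding on to its number in the physicochemical assay. They also leave open how an amide in this place, rather than an ester, would behave in either assay.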